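The source may report more compounds than this note shows. Statements on the series, on what has been measured and on what is new or still open speak of the compounds shown alone.

Compound 3 `O=C(C1=C(Nc2ccc(Br)cc2)C(=O)N(CCCn2ccnc2)C1c1ccc(Br)cc1)c1ccccc1` sits at the low end of the three measured numbers in a functional assay on U2OS cells (Homo sapiens) for antiproliferative activity, read by MTT assay, with a stated time of 72 h (on this read-out lower numbers stand for stronger inhibition and higher numbers for weaker inhibition), giving 13000 nM, though its distances to both other compounds are within the scatter. Compound 1 `CCOC1=C(C(=O)c2ccccc2)C(c2ccc(Br)cc2)N(CCCn2ccnc2)C1=O` gives 21900 nM, and compound 2 `CC(C)OC1=C(C(=O)c2ccccc2)C(c2ccc(Br)cc2)N(CCCn2ccnc2)C1=O` gives 24800 nM; the steps of a 1.7-fold lower number from compound 1 to compound 3 (0.23 log units; within the scatter) and a 1.9-fold lower number from compound 2 to compound 3 (0.28 log units; within the scatter) are within the scatter, as is a 1.1-fold higher number from compound 1 to compound 2 (0.05 log units; within the scatter). Compound 4 `O=C(C1=C(Nc2ccc(OC(F)(F)F)cc2)C(=O)N(CCCn2ccnc2)C1c1ccc(Br)cc1)c1ccccc1` differs from compound 3 by trifluoromethoxy in place of bromo on an aromatic carbon. Going by the values given here, no measured step alters this group; the two steps that exchanged an ethoxy or isopropoxy group for the (4-bromophenyl)amino group stayed within the scatter, so in this assay a step no larger than the scatter is expected, in no particular direction. Compound 4 is therefore estimated at 13000 nM, in a range from 4500 nM to 38000 nM, an expected step of no change at the digits printed from compound 3 to compound 4 (within the scatter).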

Compound 4, half-maximal inhibitory concentration: 11500 nM
Compound 4: the middle estimate sits 1.1-fold (0.05 log units) above what was measured; the range from low to high includes it.
By their numbers in this assay, from the lowest: compounds 4, 3, 1 and 2 (each within the scatter of the next, the first and the last beyond it).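

In this assay the change from bromo to trifluoromethoxy gives a 1.1-fold lower number from compound 3 to compound 4 (0.05 log units; within the scatter) and so shows that this aromatic carbon, para to a large group, takes five heavy atoms in place of one without a readable change. Going by these compounds alone, the (4-(trifluoromethoxy)phenyl)amino group in place of isopropoxy gives a 2.2-fold lower number from compound 2 to compound 4 (0.33 log units; beyond the scatter) and is the first step in this set beyond the scatter, though a modest one, whereas in place of ethoxy it gives a 1.9-fold lower number from compound 1 to compound 4 (0.28 log units; within the scatter) and stays within the scatter. As far as these compounds go, how an amine or a carboxylic acid on this aromatic carbon would read remains open. Nothing available here accounts for the size of these steps.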